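The source may hold more compounds than are shown below. What is called first, only, known or untested is meant among the compounds shown, and "the series" means these compounds.

Measured so far in a physicochemical assay for solubility, in phosphate buffer, at pH 7.4; a lower number here means a less soluble compound, a higher number a more soluble compound (each value a limit and not a number):
Compound 1 `CCOC(=O)c1c(-c2ccccc2Cl)[nH]c2cccc(OC)c2c1=O` gives > 100000 nM as a limit
Compound 2 `CCOC(=O)c1c(-c2cccc(Cl)c2)[nH]c2cccc(OC)c2c1=O` gives > 100000 nM as a limit
Compound 3 `CCOC(=O)c1c(-c2cccc(OC)c2)[nH]c2cccc(OC)c2c1=O` gives > 100000 nM as a limit

Compound 3 therefore offers no number to work from and stands at the limit of > 100000 nM in this assay, at which 3 of the 3 values shown sit, with no ranking against compound 1 or compound 2.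

The change to compound 4 `CCOC(=O)c1c(-c2cccc(C)c2)[nH]c2cccc(OC)c2c1=O` is methyl in place of methoxy on an aromatic carbon on an aromatic carbon of a six-membered aromatic ring of carbon only, meta to a large group, in short 3-methoxyphenyl to 3-methylphenyl.

Going by the values given here, three measured steps bear on it. The closest is a step that the two limits leave unreadable from compound 2 to compound 3 for methoxy in place of chloro on an aromatic carbon. The other two are a step that the two limits leave unreadable from compound 1 to compound 2 and a step that the two limits leave unreadable from compound 1 to compound 3 and neither offers a size. Among the compounds with values here, each swap of this kind has so far left the compound at the same limit, and no measured compound goes against that.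

On this basis no step beyond the scatter is expected in this assay and no direction can be given, and another limit is the likeliest report. The expected size is a number no higher from compound 3 to compound 4 (the limit leaves the size open) as an estimate only. For compound 4 the expected value is 100000 nM with an estimated range from 50000 nM to 200000 nM in this assay.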

Compound 4, solubility: > 100000 nM
Compound 4 ended at the assay's limit (the forecaster's own chance of this, stated with the estimate: 80%); the middle value lies on the limit itself.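

In this assay compound 4 gives > 100000 nM as a limit. No step from compound 1, compound 2 or compound 3 to compound 4 can be read, since all four compounds share the same limit: the limit of > 100000 nM in this assay, at which 4 of the 4 values shown sit.

The compounds shown leave open how far the solubility of each lies past that limit, and whether 2-chlorophenyl, 3-chlorophenyl, 3-methoxyphenyl and 3-methylphenyl differ at all.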